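Swapping the Side Chain on the Shared Core

The compounds below may be only part of what the source reports. "The series", "measured", "known", "first", "only" and "open" are said of these compounds alone.

Compound 1 `O=S(=O)(/C=C/c1ccccc1)Nc1ccccc1`: 10000 nM
Compound 2 `COC(=O)CNc1cc(NS(=O)(=O)/C=C/c2c(OC)cc(OC)cc2OC)ccc1OC`: 350 nM

Both compounds were tested in a functional assay on DU-145 cells (Homo sapiens) for cytotoxicity, read by trypan blue exclusion, with a stated time of 96 h; on this read-out lower numbers stand for stronger inhibition and higher numbers for weaker inhibition. In this assay compound 1 gives 10000 nM, while compound 2 gives 350 nM. Of the two numbers, compound 2 holds the lower one, and the gap between compound 1 and compound 2 is beyond the usual scatter, so compound 2 is the more potent of the pair on this read-out.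

The next compound keeps the whole of compound 2 except for one group. Compound 3 `COc1cc(OC)c(/C=C/S(=O)(=O)Nc2ccc(OC)c(NC(C(=O)O)c3ccccc3)c2)c(OC)c1` differs from compound 2 as follows: carboxy(phenyl)methyl in place of (methoxycarbonyl)methyl on a nitrogen on an aromatic ring. For the measured compounds named here, no measured pair in this set shows the effect of such a swap, so the step can only be guessed from the one value of compound 2 in this assay.

With nothing measured to lean on, the step from compound 2 to compound 3 is expected to be small, likely within the scatter, perhaps a slight move toward weaker inhibition: a 1.4-fold higher number from compound 2 to compound 3 (0.15 log units; within the scatter). Compound 3 is therefore estimated at 500 nM in this assay, with a range from 150 nM to 2000 nM.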

Compound 3, half-maximal inhibitory concentration: 75 nM
Compound 3: the middle estimate sits 6.7-fold (0.82 log units) above what was measured; the measured number lies below the stated range.
By their numbers in this assay, from the lowest: compound 3; then compound 2; then compound 1.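

Replacing (methoxycarbonyl)methyl with carboxy(phenyl)methyl on the nitrogen on the aromatic ring gives a 4.7-fold lower number from compound 2 to compound 3 (0.67 log units; beyond the scatter) in this assay and so moves the result toward stronger inhibition. This shows that the position does not merely accept a change of side chain: a group with 10 heavy atoms, including one six-membered aromatic ring of carbon only, can stand where the 5 heavy atoms of the smaller group stood, and the number still falls beyond the usual scatter. No measurement of any property or of how the compounds act accompanies this result, so the data give no explanation for the step.

The swap alters two things at once, since the methyl ester becomes a carboxylic acid and a phenyl ring appears on the carbon attached to the nitrogen, so the compounds shown cannot assign the step to either feature alone. Carboxymethyl and (methoxycarbonyl)(phenyl)methyl on the same nitrogen would separate those two features, while a longer chain carrying the carboxylic acid would test how much the distance from the shared core matters.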